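The source may report more compounds than this note shows. Statements on the series, on what has been measured and on what is new or still open speak of the compounds shown alone.

Measured in an assay on membranes from brain for displacement of a labelled ligand from Sigma intracellular receptor 2 (Rattus norvegicus), read by radioligand binding, with a stated time of 120 min, in the presence of a further agent that is not named here; a higher number here means a weaker inhibitor, a lower number a stronger inhibitor:
compound 1 `Cn1c(=O)n(CCCCN2CCN(C3CCCCC3)CC2)c2ccccc21` gives 2.57 nM
compound 2 `CCCCCn1c(=O)n(CCCCN2CCN(c3ccc(F)cc3)CC2)c2ccccc21` gives 4.27 nM
compound 3 `CC(=O)c1ccc2c(c1)n(C)c(=O)n2CCCCN1CCN(c2ccc(F)cc2)CC1` gives 7.6 nM

Compound 3 holds the highest of the three numbers in this assay; its gap to compound 2 is within the scatter, its gap to compound 1 beyond it. Compound 4 `CCCCCCCCCCn1c(=O)n(CCCCN2CCN(c3ccc(F)cc3)CC2)c2ccc(C(C)=O)cc21` is not yet measured. It differs from compound 3 by nonyl in place of hydrogen on a saturated chain carbon bound to an aromatic nitrogen. Among the measured compounds shown here, no pair in the set shows a change of this kind, so no measured step supports a direction. The expectation is a step within the scatter, if anything toward a lower number, because compound 2, with a longer chain at that position, gives 4.27 nM. Compound 4 is therefore expected at 5 nM in this assay, with a range from 1.5 nM to 20 nM, a step of a 1.5-fold lower number from compound 3 to compound 4 (0.18 log units; within the scatter).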

Compound 4, inhibition constant: 32.5 nM
For compound 4 the middle estimate is 6.5-fold (0.81 log units) below the measured one; measured number outside the range, above it.
By their numbers in this assay, from the lowest: compounds 1, 2 and 3 (each within the scatter of the next, the first and the last beyond it); then compound 4.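

In this assay, among the compounds shown here, the change from methyl to decyl, read as nonyl in place of hydrogen on a saturated chain carbon bound to an aromatic nitrogen, gives a 4.3-fold higher number from compound 3 to compound 4 (0.63 log units; beyond the scatter) as the first measured step at this position. The step runs toward a weaker inhibitor, so this position is not indifferent to chain length. Nothing at hand explains the step.

Open, as far as these compounds go, is whether the number climbs gradually or abruptly across a butyl or hexyl chain on this core. Also open, from the compounds shown here alone, is how a decyl chain ending in an amine or a carboxylic acid would read.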